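Purine anticonvulsants: formyl(methyl)amino replaces cyclopentylamino

The source may hold more compounds than are shown below. What is called first, only, known or untested is meant among the compounds shown, and "the series" means these compounds.

Working notes on a small anticonvulsant series. Compound 1 `CNc1ncnc2c1ncn2Cc1cc(F)ccc1F` gives 4 mg/kg in a functional assay on the whole organism with Rattus norvegicus as the target, in the maximal electroshock model; a lower number here means that less compound is needed, a higher number that more compound is needed for the effect. Compound 2 `Fc1ccccc1Cn1cnc2c(NC3CCCC3)ncnc21` gives 8 mg/kg in this assay, the highest of the two numbers at hand, though the gap to compound 1 lies within the scatter, so the two measured compounds are best read as equivalent on this read-out. Among the compounds with values here, no pair of measured compounds differs in a single place, so no isolated structural step has yet been quantified.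

Compound 3 `CN(C=O)c1ncnc2c1ncn2Cc1ccccc1F` is the next compound to be run in this assay. Its difference from compound 2 is formyl(methyl)amino in place of cyclopentylamino on an aromatic carbon. The entering group is smaller and carries no hydrogen-bond donor, while keeping one acceptor. Within the data shown here, nothing measured so far isolates the effect of such a change at this position, so the expected step is modest and without a firm direction. The expected step of a 1.1-fold higher number from compound 2 to compound 3 (0.05 log units; within the scatter) is estimated to stay within the scatter, with some chance of a small increase. Compound 3 is accordingly estimated at 9 mg/kg, with a range from 3 mg/kg to 25 mg/kg.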

Compound 3, dose for half-maximal effect: 11 mg/kg
Compound 3: the middle estimate sits 1.2-fold (0.09 log units) below what was measured; measured number inside the range.
By their numbers in this assay, from the lowest: compounds 1, 2 and 3 (each within the scatter of the next, the first and the last beyond it).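

Within the data shown here, the exchange of cyclopentylamino for formyl(methyl)amino gives the first single-place step, and in this assay that step (a 1.4-fold higher number from compound 2 to compound 3 (0.14 log units; within the scatter)) stays within the scatter, so compound 2 and compound 3 read as equivalent. This aromatic carbon of the shared core therefore accepts a group with no ring and no hydrogen-bond donor in place of one that has both, without a difference beyond the scatter in this read-out. No measurement at hand accounts for this outcome.

As far as these compounds go, the ring and the hydrogen-bond donor leave together in this one step, so their separate contributions remain open; a plain amino group, dimethylamino or acetyl(methyl)amino on the same carbon would begin to pull them apart. From the compounds shown here alone, compound 1 differs from compound 2 and compound 3 in more than one place, so the steps to it cannot be read, and it remains open whether the equivalence seen here carries over to the substitution pattern on the fluorinated benzyl group of compound 1.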